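Compound 3 to a pyridin-4-yl urea: solubility expected

The compounds below may be only part of what the source reports. "The series", "measured", "known", "first", "only" and "open" are said of these compounds alone.

Compound 1 `O=C(Nc1ccc(F)c(C(F)(F)F)c1)Nc1cnccn1`: < 1.6 ug/mL (a limit)
Compound 2 `O=C(Nc1ccc(F)c(C(F)(F)F)c1)Nc1ccccn1`: < 1.6 ug/mL (a limit)
Compound 3 `Cc1cc(NC(=O)Nc2ccc(F)c(C(F)(F)F)c2)on1`: 6.3 ug/mL

All three compounds were read in a physicochemical assay for solubility, read by nephelometry, in phosphate buffer, measured as kinetic solubility, at pH 6.5; a higher number here means a more soluble compound, a lower number a less soluble compound. Compound 3 stands alone with a true number, 6.3 ug/mL, and it is the only one of the three that does. Compound 1 gives only a limit, < 1.6 ug/mL. Compound 2 likewise gives only a limit, < 1.6 ug/mL. The floor of the read-out therefore shapes the picture: the limit of < 1.6 ug/mL in this assay, at which 2 of the 3 values shown sit.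

Compound 4 `O=C(Nc1ccncc1)Nc1ccc(F)c(C(F)(F)F)c1` has pyridin-4-yl in place of 3-methyl-1,2-oxazol-5-yl on an amide-type nitrogen.

Among the compounds with values here, two measured steps bear on this change, both of them running into compound 3: an at least 3.9-fold higher number from compound 1 to compound 3 (0.59 log units; beyond the scatter) and an at least 3.9-fold higher number from compound 2 to compound 3 (0.59 log units; beyond the scatter). The second is the closer guide, since compound 2 also carries a pyridine, as pyridin-2-yl. The step between the two limited compounds, a step that the two limits leave unreadable from compound 1 to compound 2, adds nothing. Read backwards, these steps suggest a fall in this assay of modest size, and a reading that returns only a limit is quite possible. The expected change is a 2.1-fold lower number from compound 3 to compound 4 (0.32 log units; beyond the scatter). For compound 4 the estimated value is 3 ug/mL, with an expected range of 1.6 ug/mL to 8 ug/mL.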

Compound 4, solubility: 6.3 ug/mL
For compound 4 the middle estimate is 2.1-fold (0.32 log units) below the measured one; low and high end bracket the measured number.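

In this assay, pyridin-4-yl in place of 3-methyl-1,2-oxazol-5-yl on the amide-type nitrogen gives no change at the digits printed from compound 3 to compound 4 (within the scatter), so a true reading at this place is not confined to the five-membered ring of compound 3. The six-membered rings do not all read alike here, since pyridin-4-yl in place of pyridin-2-yl gives an at least 3.9-fold higher number from compound 2 to compound 4 (0.59 log units; beyond the scatter) and pyridin-4-yl in place of pyrazin-2-yl gives an at least 3.9-fold higher number from compound 1 to compound 4 (0.59 log units; beyond the scatter). Compound 1 and compound 2 each give only a limit, so these two steps set a lower bound and not a true size: the limit of < 1.6 ug/mL in this assay, at which 2 of the 4 values shown sit.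

The compounds shown leave open how pyridin-3-yl would read at this place, and so whether compound 4 stands apart from the other pyridine in the set or marks a wider trend among pyridines. Also open, from the compounds shown here alone, is whether a dimethylamino group or a carboxylic acid set on the pyridin-4-yl ring would move the reading away from the value that compound 4 gives, 6.3 ug/mL.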